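The source may hold more compounds than are shown below. What is called first, only, known or untested is meant among the compounds shown, and "the series" means these compounds.

Working notes on the series. In a physicochemical assay for solubility (a lower number here means a less soluble compound, a higher number a more soluble compound), compound 1 `CNC(=O)c1cc(C(=O)NC2CC2)cn(CC2CCCCC2)c1=O` gives >= 148 ug/mL as a limit and not a number. Compound 2 `CNC(=O)c1cc(C(=O)NC2CC2)cn(Cc2cccc(C)c2)c1=O` gives >= 205 ug/mL as a limit too. Compound 3 `CNC(=O)c1cc(C(=O)NC2CC2)cn(CC2CCCOC2)c1=O` gives >= 131 ug/mL as a limit as well, so it has no number of its own and stands like the other two.

Compound 4 `CNC(=O)c1cc(C(=O)NC2CC2)cn(Cc2ccc3nc[nH]c3c2)c1=O` differs from compound 3 in one place by 1H-benzimidazol-6-yl in place of oxan-3-yl on a saturated chain carbon bound to an aromatic nitrogen in these words: 1H-benzimidazol-6-yl in place of oxan-3-yl on a saturated chain carbon bound to an aromatic nitrogen.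

For the measured compounds named here, three measured steps bear on this change, all at that same place. One is a step that the two limits leave unreadable from compound 1 to compound 2 and another is a step that the two limits leave unreadable from compound 1 to compound 3 while the closest is a step that the two limits leave unreadable from compound 2 to compound 3 as it also exchanges an aromatic group and oxan-3-yl. None of the three has a readable size, so no size carries over to the new step. No step beyond the scatter is therefore expected in this assay and these steps give no direction. The expected step is a step that the limit leaves unreadable from compound 3 to compound 4 and it is only an estimate resting on a limit. For compound 4 the estimated value is 150 ug/mL with an expected range from 60 ug/mL to 320 ug/mL in this read-out.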

Compound 4, solubility: >= 163 ug/mL
Compound 4: only a limit was reported; the forecaster's own chance of this, stated with the estimate: 60%; middle value at least 1.0-fold (0.03 log units) from the limit.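

In this assay compound 4 gives >= 163 ug/mL, a limit and not a number. The steps linking it to compound 1, compound 2 and compound 3 therefore cannot be read. The compounds shown leave open how far any of the four lies from its limit, and whether the exchanged group shifts this read-out at all.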